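One more methyl on the aromatic nitrogen

A few compounds are considered here, and "the series" means these few. Any claim that something is new, unique, unknown or untested is made for them only; others in the source may bear on it.

Measured so far in a functional assay on the whole organism with Rattus norvegicus as the target (on this read-out higher numbers stand for an effect only at larger amounts of compound and lower numbers for an effect already at smaller amounts), are these compounds:
Compound 1 `CCN(CCNC(=O)c1cc(Cl)c(N)cc1OC)Cc1ccccc1Cl` (10 mg/kg)
Compound 2 `CCN(CCNC(=O)c1cc(Cl)c(N)cc1OC)Cc1ccc(F)cc1` (0.2 mg/kg)
Compound 3 `CNc1cc(OC)c(C(=O)NCCN(C)Cc2ccccc2)cc1Cl` (0.21 mg/kg)

Compound 3 (0.21 mg/kg) and compound 2 (0.2 mg/kg) lie within the usual scatter of each other, while compound 1 (10 mg/kg) stands far above both. Compound 4 `COc1cc(N(C)C)c(Cl)cc1C(=O)NCCN(C)Cc1ccccc1` takes compound 3 and puts methyl in place of hydrogen on a nitrogen on an aromatic ring, turning methylamino to dimethylamino.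

Among the measured compounds shown here, only one measured step changes a single place (a 50-fold lower number from compound 1 to compound 2 (1.70 log units; beyond the scatter)). It swaps 2-chlorophenyl for 4-fluorophenyl, not anything on this nitrogen, so it gives no direct guide. For the measured compounds named here, it shows only that one small change can move the numbers a long way. Going by the values given here, no measured compound carries dimethylamino, so the direction remains uncertain. A moderate move toward a higher number is expected in this assay (a 3.8-fold higher number from compound 3 to compound 4 (0.58 log units; beyond the scatter)), meaning more compound would be needed. The estimated value for compound 4 is (0.8 mg/kg), with an expected range from (0.15 mg/kg) to (5 mg/kg).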

Compound 4, dose for half-maximal effect: 0.54 mg/kg
Beside the measured number, compound 4's estimate is 1.5-fold (0.17 log units) above it; the range from low to high includes it.
By their numbers in this assay, from the lowest: compounds 2 and 3 (each within the scatter of the next); then compound 4; then compound 1.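

In this assay, among the compounds shown here, the step from methylamino to dimethylamino gives a 2.6-fold higher number from compound 3 to compound 4 (0.41 log units; beyond the scatter), the first measured change on this nitrogen on the aromatic ring. It shows that this position responds to a single added methyl, although only modestly: the change is beyond the scatter, and a little more compound is needed for the same effect. The added methyl brings no hydrogen-bond donor or acceptor and no net charge, and no measurement at hand gives a reason for the rise.

One step cannot show whether a larger group here, such as propyl or acetyl, would raise the number further. Also open, going by these compounds, is how a plain amino group, as carried by compound 1 and compound 2, would compare with methylamino on the rest of compound 3.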